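This account rests on a few compounds, and the source may have more. Where it says the series, first, only, none or still open, it means among the compounds named here.

The study concerns two measured compounds and one that is still to be tested. Compound 2, with the structure `Cc1ccc(C(=O)N2NC(=O)/C(=C\c3ccc(O)cc3)N=C2c2ccccc2)cc1`, carries a hydroxy on one of its aryl rings, and in a functional assay on the whole organism (strain albino) with Mus musculus as the target, with a stated time of 4 h (on this read-out higher numbers stand for an effect only at larger amounts of compound and lower numbers for an effect already at smaller amounts), compound 2 gives 100 mg/kg. Compound 1, the structure `Cc1ccc(/C=C2/N=C(c3ccccc3)N(C(=O)COc3ccccc3)NC2=O)cc1`, differs from it in two places at once, and in this assay compound 1 gives 300 mg/kg; of the two numbers, that of compound 2 is the lower one, and the gap between the two lies beyond the usual scatter.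

Compound 3, with the structure `Cc1ccc(/C=C2/N=C(c3ccccc3)N(C(=O)c3ccc(C)cc3)NC2=O)cc1`, arises from compound 2 by a single change, (methyl in place of hydroxy on an aromatic carbon), that is, methyl in place of hydroxy on an aromatic carbon. Among the compounds with values here, no measured pair shows this change alone, so its size can only be guessed. Compound 1 also bears the methyl at that position but differs in a second place, so it gives only a loose hint. The step from compound 2 to compound 3 is expected to be a 2.0-fold higher number from compound 2 to compound 3 (0.30 log units; within the scatter), toward a higher number, of a size near the edge of the scatter. For compound 3 the expected value in this assay is 200 mg/kg, in a range from 80 mg/kg to 500 mg/kg.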

Compound 3, dose for half-maximal effect: 100 mg/kg
Compound 3: the middle estimate sits 2.0-fold (0.30 log units) above what was measured; measured number inside the range.
By their numbers in this assay, from the lowest: compounds 2 and 3 (each within the scatter of the next); then compound 1.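

In this assay the exchange of 4-hydroxyphenyl for 4-methylphenyl can now be read on its own, and it gives no change at the digits printed from compound 2 to compound 3 (within the scatter) at this site, para to a large group. A hydroxy, which counts as one hydrogen-bond donor and one hydrogen-bond acceptor, and a methyl, which counts as neither, are thus not told apart here by this read-out. Within the data shown here, compound 3 also provides the first single-place comparison at the carbonyl carbon, where 4-methylphenyl in place of phenoxymethyl gives a 3.0-fold lower number from compound 1 to compound 3 (0.48 log units; beyond the scatter) and so places a step beyond the scatter at that group; no outside data bear on either step, and what lies behind them remains unknown.

From the compounds shown here alone, it remains open whether an amine, a carboxylic acid or a methoxy group on the same aromatic carbon would also leave the number in this assay where it stands, since only hydroxy and methyl are compared there. Going by these compounds, it is equally open whether a longer chain or a benzyl group on the carbonyl carbon would fall nearer to compound 1 or to compound 3.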